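From 3,4-dimethoxyphenyl to naphthalen-2-yl on a shared core

The compounds below may be only part of what the source reports. "The series", "measured", "known", "first", "only" and "open" are said of these compounds alone.

Within the data shown here, in a functional assay on WM 266-4 cells (Homo sapiens) for antiproliferative activity, read by MTT assay, with a stated time of 24 h (a lower number here means a stronger inhibitor of growth, a higher number a weaker inhibitor of growth), compound 1 `COc1ccc(C2CC(c3ccc4c(c3)OCCO4)=NN2c2ccccc2)cc1OC` gives 2160 nM, the higher of the two numbers available so far. The only other measured relative, compound 2 `c1ccc(COc2cccc(C3CC(c4ccc5c(c4)OCCO5)=NN3c3ccccc3)c2)cc1`, gives 870 nM, and this gap lies beyond the usual scatter of repeated measurements. Compound 3 `c1ccc(N2N=C(c3ccc4c(c3)OCCO4)CC2c2ccc3ccccc3c2)cc1` keeps the rest of compound 1 but carries naphthalen-2-yl in place of 3,4-dimethoxyphenyl on a saturated ring carbon. Among the measured compounds shown here, no measured pair differs in just one place, so this swap has no direct precedent. Compound 2 also lacks the 3,4-dimethoxyphenyl group and gives 870 nM, which makes a move toward a lower number seem somewhat more likely than the reverse. The expected change, a 1.8-fold lower number from compound 1 to compound 3 (0.26 log units; within the scatter), is estimated to stay within the scatter. For compound 3, the expected value is 1200 nM, with an estimated range from 400 nM to 3500 nM.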

Compound 3, concentration for 50% growth inhibition: 13900 nM
The estimate for compound 3 lay 12-fold (1.06 log units) below the measured number, and the stated range ends below it.
By their numbers in this assay, from the lowest: compound 2; then compound 1; then compound 3.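

In this assay, replacing 3,4-dimethoxyphenyl with naphthalen-2-yl on this saturated ring carbon gives a 6.4-fold higher number from compound 1 to compound 3 (0.81 log units; beyond the scatter) and so weakens growth inhibition. Both groups hold 10 heavy atoms, so the heavy-atom count alone does not set the number at this position. No measurement shown here explains the shift.

The group that leaves has two oxygen atoms and one aromatic ring, while the group that enters has only carbon and two aromatic rings, so this single swap cannot separate the loss of the oxygens from the gain of the second ring. A plain phenyl group or a quinolinyl group on the same carbon would help pull those two changes apart.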